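The source may report more compounds than this note shows. Statements on the series, on what has been measured and on what is new or still open speak of the compounds shown alone.

Values measured in a functional assay on HL-60 cells (Homo sapiens) for inhibition, read by MTT assay, with a stated time of 72 h (on this read-out higher numbers stand for weaker inhibition and lower numbers for stronger inhibition), are these:
- compound 1 (`COc1cc(OC)cc(N2CCN(C(=O)c3onc(C)c3-c3ccccc3F)CC2)c1`) gives 165 nM
- compound 2 (`COc1cccc(N2CCN(C(=O)c3oc(C)nc3-c3ccccc3F)CC2)c1`) gives 56.1 nM
- compound 3 (`Cc1nc(-c2ccccc2)c(C(=O)N2CCN(c3ccc(F)cc3)CC2)o1`) gives > 1000 nM as a limit of the assay, not a number

Of the two true numbers, compound 1 has the higher one. The gap down to compound 2 lies beyond the scatter, so compound 1 is the weaker inhibitor of that pair.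

Compound 4 (`COc1cc(OC)cc(N2CCN(C(=O)c3onc(C)c3-c3ccc(-c4ccco4)cc3)CC2)c1`) has not yet been measured. It keeps the core of compound 1 but carries 4-(furan-2-yl)phenyl in place of 2-fluorophenyl on an aromatic carbon of the shared core.

Within the data shown here, no measured pair changes this group alone, so the data give no direct size for such a swap. Starting from compound 1 at 165 nM as the reference, a moderate step towards weaker inhibition in this assay is expected, though this is a loose expectation. The estimated step is a 1.8-fold higher number from compound 1 to compound 4 (0.26 log units; within the scatter) and its size is uncertain. For compound 4 the estimated value is 300 nM with an expected range from 70 nM to 1300 nM in this read-out.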

Compound 4, half-maximal inhibitory concentration: 191 nM
Compound 4: the middle estimate sits 1.6-fold (0.20 log units) above what was measured; the range from low to high includes it.
By their numbers in this assay, from the lowest: compound 2; then compounds 1 and 4 (each within the scatter of the next). At a limit, above all of these: compound 3.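

In this assay the swap gives a 1.2-fold higher number from compound 1 to compound 4 (0.06 log units; within the scatter) and so stays within the scatter. This aromatic carbon of the shared core therefore carries 4-(furan-2-yl)phenyl, with 11 heavy atoms and a second aromatic ring, as well as it carries 2-fluorophenyl, with 7 heavy atoms, and the reading shows no real difference. The earlier compounds shown here could not show this, as no measured pair among them changed this group alone.

Going by these compounds, whether a group such as 4-aminophenyl or 4-carboxyphenyl at this carbon would read the same remains open, as does the outcome with a group as small as methyl. Nothing measured here explains why compound 1 and compound 4 read alike.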